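Cyano for methyl on the furan of compound 2

This account rests on a few compounds, and the source may have more. Where it says the series, first, only, none or still open, it means among the compounds named here.

Three compounds of the series have numbers in a functional assay on CHO-K1 cells for antagonist activity at adenosine receptor A1 (Homo sapiens), read by a beta-galactosidase reporter and cAMP accumulation, with stated times of 15 min and 6 h; on this read-out higher numbers stand for weaker inhibition and lower numbers for stronger inhibition. Compound 1 `Cc1ccc(-c2nc(N)c3ccsc3n2)o1` gives 493 nM. Compound 2 `Cc1ccc(-c2nc(N)c3cc(Cc4ccccc4)sc3n2)o1` gives 298 nM, and compound 3 `Cc1ccc(-c2nc(N)c3cc(Cc4ccccc4Cl)sc3n2)o1` gives 26.1 nM. Compound 2 therefore stands second highest of the three: its nearest neighbour is compound 1, with a 1.7-fold lower number from compound 1 to compound 2 (0.22 log units; within the scatter), whereas an 11-fold lower number from compound 2 to compound 3 (1.06 log units; beyond the scatter) sets compound 3 well apart. The remaining measured step, a 19-fold lower number from compound 1 to compound 3 (1.28 log units; beyond the scatter), is likewise large.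

Compound 4 `N#Cc1ccc(-c2nc(N)c3cc(Cc4ccccc4)sc3n2)o1` differs from compound 2 by cyano in place of methyl on an aromatic carbon. All three measured steps concern the other end of the shared core, namely the benzyl, the 2-chlorobenzyl and the chloro on the benzyl; not one of them alters the furan substituent. Going by the values given here, there is thus no measured step that bears on this change, and the series gives no ground to expect a shift in this assay beyond the scatter in either direction; the range is set wide to reflect that the change is untested.

Compound 4 is estimated at 350 nM, with a range from 90 nM to 1400 nM. The expected step is a 1.2-fold higher number from compound 2 to compound 4 (0.07 log units; within the scatter).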

Compound 4, inhibition constant: 3160 nM
Compound 4: middle estimate off by 9.0-fold (0.96 log units), on the low side; measured number above the stated range.
By their numbers in this assay, from the lowest: compound 3; then compounds 2 and 1 (each within the scatter of the next); then compound 4.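

In this assay, the group on the aromatic carbon next to the ring oxygen proves able to move the number on its own: the change from 5-methylfuran-2-yl to 5-cyanofuran-2-yl gives an 11-fold higher number from compound 2 to compound 4 (1.03 log units; beyond the scatter). This step runs in the opposite direction to an 11-fold lower number from compound 2 to compound 3 (1.06 log units; beyond the scatter), so the two ends of the molecule can each shift the number, one downward through the chloro on the benzyl and the other upward through the cyano. Compounds 1, 2 and 3 all carry methyl at this position and could not show this, and nothing in hand explains the rise seen with cyano.

As far as these compounds go, the cyano step has been read only against the benzyl of compound 2, so it remains open whether the same change would carry over to the 2-chlorobenzyl of compound 3 or to the hydrogen of compound 1. From the compounds shown here alone, with only methyl and cyano compared at this position, it is also open where hydrogen, ethyl, an aminomethyl group or a carboxylic acid would fall, and whether any group here would give a lower number than methyl does.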